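From Amide to Urea in a Growth Inhibition Series

The source may report more compounds than this note shows. Statements on the series, on what has been measured and on what is new or still open speak of the compounds shown alone.

Three compounds built on one shared core were tested in a functional assay on K562 cells (Homo sapiens) for inhibition, read by sulforhodamine B assay, with a stated time of 48 h; on this read-out lower numbers stand for stronger inhibition of growth and higher numbers for weaker inhibition of growth. Compound 1 `COc1cc(-c2nn(-c3cccc(NC(=O)Nc4cc(C(F)(F)F)cc(C(F)(F)F)c4)c3)cc2-c2ccncc2)ccc1Cl` carries a urea link to a bis(trifluoromethyl)phenyl group, and in this assay compound 1 gives 3250 nM. Compound 3 `O=C(Nc1cccc(-n2cc(-c3ccncc3)c(-c3ccc(Cl)c(O)c3)n2)c1)Nc1cc(C(F)(F)F)cc(C(F)(F)F)c1` differs from compound 1 only by hydrogen in place of methyl on an oxygen on an aromatic ring, and compound 3 gives 3930 nM. That change amounts to a 1.2-fold higher number from compound 1 to compound 3 (0.08 log units; within the scatter).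

Compound 2 `COc1cc(-c2nn(-c3cccc(NC(=O)c4cccc(C(F)(F)F)c4)c3)cc2-c2ccncc2)ccc1Cl` carries an amide instead of a urea. For compound 2 this assay reports only a limit, not a number: > 50000 nM. Compound 2 sits at the limit of > 50000 nM in this assay, at which 1 of the 3 values shown sits.

Compound 4 `COc1cc(-c2nn(-c3cccc(NC(=O)Nc4ccc(Cl)c(C(F)(F)F)c4)c3)cc2-c2ccncc2)ccc1Cl` has not yet been measured. It differs from compound 2 by (4-chloro-3-(trifluoromethyl)phenyl)amino in place of 3-(trifluoromethyl)phenyl on a carbonyl carbon, which turns the amide into a urea. Within the data shown here, the one measured step, from methyl to hydrogen on the oxygen, does not touch this link and so offers no guide to it. What the numbers do show is that both ureas gave measurable values while the amide reached only the limit.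

Compound 4 is therefore expected to give about 4000 nM, within a range from 1200 nM to 15000 nM, because compound 1 gives 3250 nM with the same urea link. This corresponds to an expected step of an at least 12-fold lower number from compound 2 to compound 4 (1.09 log units; beyond the scatter).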

Compound 4, concentration for total growth inhibition: > 32500 nM
Compound 4 gave a limit, no number (the forecaster's own chance of this, stated with the estimate: 15%); middle value at least 8.1-fold (0.90 log units) away from the limit.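

In this assay, compound 2 and compound 4 both give only a limit of the assay and not a number, so the step between these two compounds cannot be read. The compounds shown leave open whether the change from the amide of compound 2 to the urea of compound 4 alters growth inhibition at all.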